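A few compounds are considered here, and "the series" means these few. Any claim that something is new, unique, unknown or untested is made for them only; others in the source may bear on it.

The measured compounds:
Compound 1, `CO[C@@H](C)c1c(NC(=O)Nc2cnc(-n3nccn3)c(Cl)c2)cnc2cc(Cl)nn12`. In an ADME assay on microsomes from liver (Homo sapiens) for metabolic stability (a higher number here means faster removal of the compound, a lower number slower removal), compound 1 gives < 25 mL.min-1.g-1, which is a limit of the assay and not a number.
Compound 2, `O=C(Nc1cnc(-n2nccn2)c(Cl)c1)Nc1cnc2cc(Cl)nn2c1C1CCOCC1`. In this assay compound 2 gives < 25 mL.min-1.g-1, again a limit of the assay and not a number.

Among the compounds with values here, compound 2 therefore stands at the limit of this assay rather than at a measured point, and the only other value shown is a limit as well: the limit of < 25 mL.min-1.g-1 in this assay, at which 2 of the 2 values shown sit. Within the data shown here, the one measured step, a step that the two limits leave unreadable from compound 1 to compound 2, replaced 1-methoxyethyl with oxan-4-yl on an aromatic carbon, a step whose size the two limits leave unreadable.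

The unmeasured compound 3 is `COCc1c(NC(=O)Nc2cnc(-n3nccn3)c(Cl)c2)cnc2cc(Cl)nn12`. It differs from compound 2 in one place: methoxymethyl in place of oxan-4-yl on an aromatic carbon. No measured step bears directly on this change, and the one step shown has no readable size. No step beyond the usual scatter is therefore expected in this assay . Compound 3 is estimated at 15 mL.min-1.g-1, with a range from 5 mL.min-1.g-1 to 35 mL.min-1.g-1. For compound 3 the expected step is a step that the limit leaves unreadable from compound 2 to compound 3, and a further limit rather than a number is the most likely outcome.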

Compound 3, intrinsic clearance in microsomes: < 25 mL.min-1.g-1
Compound 3: only a limit was reported (the forecaster's own chance of this, stated with the estimate: 70%); the middle value does not contradict the limit.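

Compound 3 also returns a limit of the assay and not a number, so its steps from compound 2 and from compound 1 cannot be read: the limit of < 25 mL.min-1.g-1 in this assay, at which 3 of the 3 values shown sit.

The compounds shown leave open how far compound 1, compound 2 and compound 3 really differ in this assay, and which change at this place, if any, would give a readable value.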